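From Dichlorobenzyl to Ethyl: Expecting a Larger Response

This account rests on a few compounds, and the source may have more. Where it says the series, first, only, none or still open, it means among the compounds named here.

Of the compounds shown here, three sharing one core have been measured in a functional assay on the whole organism (B cells) with Mus musculus as the target; a lower number here means a smaller maximal response, a higher number a larger maximal response. Compound 1 `Nc1nc(O)c2c(n1)n(C1OC(CO)[C@@H](O)[C@H]1O)c(=O)n2Cc1ccc(Cl)c(Cl)c1` gives 55% there, the lowest of the three numbers. Its nearest neighbour, compound 2 `CCCn1c(=O)n(C2OC(COP(=O)(O)O)[C@@H](O)[C@H]2O)c2nc(N)nc(O)c21`, gives 76%, a gap beyond the usual scatter, and the furthest, compound 3 `C=CCn1c(=O)n([C@@H]2O[C@H](CO)[C@H]3OC(CCC)(CCC)O[C@H]32)c2nc(N)nc(O)c21`, gives 123%, also beyond the scatter. No two of the measured compounds differ in one place only, so no single step can be read from them; what the numbers show is that both compounds lacking the 3,4-dichlorobenzyl stand above compound 1.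

Compound 4 `CCn1c(=O)n(C2OC(CO)[C@@H](O)[C@H]2O)c2nc(N)nc(O)c21` has not yet been measured. It differs from compound 1 in one place: methyl in place of 3,4-dichlorophenyl on a saturated chain carbon bound to an aromatic nitrogen. Because compound 2 gives 76% and compound 3 gives 123%, the step of a number 30 percentage points higher from compound 1 to compound 4 (beyond the scatter) is expected to run upward and to exceed the scatter. Compound 4 is accordingly estimated to reach 85% in this assay, with a likely range from 55% to 120%.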

Compound 4, largest response reached (reported as maximal response), in percent of the reference or control that the assay uses: 82%
Estimate against measurement, compound 4: 3 percentage points above; the range from low to high includes it.
By their numbers in this assay, from the lowest: compound 1; then compounds 2 and 4 (each within the scatter of the next); then compound 3.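

Among these compounds, compound 1 and compound 4 form the only pair here that differs in a single place, so the effect of this change can now be read directly. In this assay, replacing 3,4-dichlorobenzyl with ethyl on the shared core gives a number 27 percentage points higher from compound 1 to compound 4 (beyond the scatter), which shows that the maximal response at this position does not depend on the dichlorinated aromatic ring and is higher without it. Nothing available explains this step.

Going by these compounds, whether the rise comes from losing the ring or from losing the chlorine atoms remains open, and a plain benzyl would separate the two. The compounds shown also leave unsettled how a longer chain, or a chain ending in an amine, would behave at this position.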